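A few compounds are considered here, and "the series" means these few. Any claim that something is new, unique, unknown or untested is made for them only; others in the source may bear on it.

- Compound 1 `Cc1[nH]c(=O)n(C2CCCCC2)c1-c1ccc(OC(C)C)cc1`: 13000 nM
- Compound 2 `Cc1[nH]c(=O)n(C2CCCCC2)c1-c1ccc(OCCC(C)C)cc1`: 7200 nM

In a functional assay on brain (Rattus norvegicus, strain Wistar) for inhibition (on this read-out lower numbers stand for stronger inhibition and higher numbers for weaker inhibition), compound 2 gives 7200 nM, which lies within the scatter of compound 1. Compound 3 `Cc1[nH]c(=O)n(C2CCCCC2)c1-c1ccc(C2CCCCC2)cc1` is still unmeasured and carries cyclohexyl in place of isopentyloxy on an aromatic carbon. Among the compounds with values here, only one measured step bears on this change, and only loosely: a 1.8-fold lower number from compound 1 to compound 2 (0.26 log units; within the scatter), with isopentyl in place of isopropyl, keeps the oxygen that compound 3 lacks. With so little to go on, no shift beyond the scatter is expected, and the expected step is a 1.1-fold lower number from compound 2 to compound 3 (0.04 log units; within the scatter). Compound 3 is estimated at 6500 nM, with an expected range of 2000 nM to 20000 nM.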

Compound 3, half-maximal inhibitory concentration: 28900 nM
Compound 3: the middle estimate sits 4.4-fold (0.65 log units) below what was measured, outside the stated range (above it).
By their numbers in this assay, from the lowest: compounds 2 and 1 (each within the scatter of the next); then compound 3.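

In this assay, the ether chain on this aromatic carbon could vary without a shift beyond the scatter, but removing the ether altogether could not: cyclohexyl in place of isopentyloxy gives a 4.0-fold higher number from compound 2 to compound 3 (0.60 log units; beyond the scatter) and cyclohexyl in place of isopropoxy gives a 2.2-fold higher number from compound 1 to compound 3 (0.35 log units; beyond the scatter), both towards weaker inhibition. The first of these steps keeps the heavy-atom count unchanged, so size counted in that way does not track the result. No available evidence bears on this shift.

The compounds shown leave open whether losing the oxygen or gaining the ring matters more. A hexyl group and a cyclohexyloxy group at this position would separate the two.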